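Swapping a Nitrile for Methyl on the Phenyl Ring

A few compounds are considered here, and "the series" means these few. Any claim that something is new, unique, unknown or untested is made for them only; others in the source may bear on it.

Compound 3 `CC1(C)[C@H]2CC[C@]1(C)N(Cc1cn(-c3cccc(C#N)c3)nn1)C(=O)C2` gives 440 nM in a functional assay on A549 cells (Homo sapiens) for inhibition, read by MTT assay, with a stated time of 24 h (on this read-out lower numbers stand for stronger inhibition and higher numbers for weaker inhibition), the highest of the three numbers, though compound 1 `COc1ccccc1-n1cc(CN2C(=O)C[C@@H]3CC[C@@]2(C)C3(C)C)nn1` with 350 nM lies within the scatter of it, and compound 2 `CC1(C)[C@H]2CC[C@]1(C)N(Cc1cn(-c3ccccc3C#N)nn1)C(=O)C2` gives 100 nM. Compound 4 `Cc1cccc(-n2cc(CN3C(=O)C[C@@H]4CC[C@@]3(C)C4(C)C)nn2)c1` differs from compound 3 in one place: methyl in place of cyano on an aromatic carbon. For the measured compounds named here, no measured step exchanges cyano for methyl. The closest is a 3.5-fold lower number from compound 1 to compound 2 (0.54 log units; beyond the scatter), an exchange of group on an aromatic carbon, while a 4.4-fold higher number from compound 2 to compound 3 (0.64 log units; beyond the scatter) and a 1.3-fold higher number from compound 1 to compound 3 (0.10 log units; within the scatter) exchange the whole phenyl substituent. None of these bears directly on the change, so a step of about the scatter, leaning toward weaker inhibition, is expected, a 1.3-fold higher number from compound 3 to compound 4 (0.10 log units; within the scatter). Compound 4 is therefore estimated at 550 nM, within a range of 200 nM to 1500 nM.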

Compound 4, half-maximal inhibitory concentration: 50 nM
Estimate against measurement, compound 4: 11-fold (1.04 log units) above; measured number below the stated range.
By their numbers in this assay, from the lowest: compounds 4 and 2 (each within the scatter of the next); then compounds 1 and 3 (each within the scatter of the next).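

Methyl and nitrile are not interchangeable at this place on the phenyl ring: in this assay, methyl in place of cyano gives an 8.8-fold lower number from compound 3 to compound 4 (0.94 log units; beyond the scatter). The 3-methylphenyl group also gives a 7.0-fold lower number from compound 1 to compound 4 (0.85 log units; beyond the scatter), while its step from the 2-cyanophenyl group is a 2.0-fold lower number from compound 2 to compound 4 (0.30 log units; within the scatter), so a nitrile-bearing compound can sit within the scatter of compound 4. Nothing measured here explains the size of the nitrile-to-methyl step.

As far as these compounds go, it remains open whether an amine or a longer chain such as propyl on this aromatic carbon would behave like methyl or like cyano. Also open, from the compounds shown here alone, is how a methyl group would fare at the spot where the 2-cyanophenyl group carries its nitrile.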